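The source may report more compounds than this note shows. Statements on the series, on what has been measured and on what is new or still open speak of the compounds shown alone.

Measured so far:
- compound 1, `COCCOCCOCCOCCOCCOCCOCCOCCOCCOCCOC(=O)Oc1c(C(C)C)cccc1C(C)C`: 400000 nM
- compound 2, `COCCOCCOCCOC(=O)Oc1c(C(C)C)cccc1C(C)C`: 2130000 nM
- compound 3, `COCCOCCOCCOCCOCCOCCOCCOCC(=O)Oc1c(C(C)C)cccc1C(C)C`: 520000 nM

In an ADME assay on A549 cells (Homo sapiens) for cytotoxicity, read by MTT assay, with a stated time of 24 h (on this read-out higher numbers stand for an effect only at larger amounts of compound and lower numbers for an effect already at smaller amounts), compound 2 stands highest of the three numbers, beyond the scatter above both compound 3 and compound 1, so it harms the cells only at larger amounts than either. All three share the same core and differ only in the length of the chain on the carbonate oxygen; compound 2 carries the shortest chain.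

Compound 4, `COCCOCCOCCOCCOC(=O)Oc1c(C(C)C)cccc1C(C)C`, has not yet been measured. It differs from compound 2 in one place: methoxymethyl in place of hydrogen on a saturated chain carbon bound to an oxygen on a saturated carbon. The chain thus grows by a single unit, a far smaller stretch than separates compound 2 from compound 3 or compound 1.

The step from compound 2 to compound 4 is expected to be small, a 1.4-fold lower number from compound 2 to compound 4 (0.15 log units; within the scatter), pointing toward lower numbers but likely within the scatter. Compound 4 is therefore estimated at 1500000 nM, in the range from 600000 nM to 3500000 nM.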

Compound 4, half-maximal effective concentration in the A549 assay: 1360000 nM
For compound 4 the middle estimate is 1.1-fold (0.04 log units) above the measured one, and the stated range covers the measured number.
By their numbers in the A549 assay, from the lowest: compounds 1 and 3 (each within the scatter of the next); then compounds 4 and 2 (each within the scatter of the next).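

Going by these compounds alone, the step from compound 2 to compound 4 is the first comparison here in which only one place changes. In the A549 assay adding methoxymethyl in place of hydrogen gives a 1.6-fold lower number from compound 2 to compound 4 (0.19 log units; within the scatter), so this single added unit does not clearly separate the two compounds. In a physicochemical assay for solubility, in phosphate buffer, at pH 7.4 (a higher number here means a more soluble compound, a lower number a less soluble compound), compound 2 gives 190 ug/mL and compound 4 gives 380 ug/mL, which is a 2.0-fold higher number from compound 2 to compound 4 (0.30 log units; within the scatter), so no clear separation appears there either.

What lies behind these results is not addressed by any measurement available here.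

Still open, going by these compounds, is how compound 4 would compare with a chain carrying an amine or a carboxylic acid.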